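The source may report more compounds than this note shows. Statements on the series, on what has been measured and on what is new or still open speak of the compounds shown alone.

Of the compounds shown here, three of one series have been measured. Compound 1 `CSc1ccc(/C=N/n2c(Cc3ccc(S(C)(=O)=O)cc3)n[nH]c2=S)cc1` gives 71.9% in a functional assay on HeLa cells (Homo sapiens) for cytotoxicity, read by MTT assay, with a stated time of 48 h, tested at 100 uM; on this read-out higher numbers stand for a stronger effect at the one concentration tested and lower numbers for a weaker effect. Compound 2 `CS(=O)(=O)c1ccc(Cc2n[nH]c(=S)n2/N=C/c2cccnc2)cc1` gives 45.1% in this assay, and compound 3 `CS(=O)(=O)c1ccc(Cc2n[nH]c(=S)n2/N=C/c2ccc(F)cc2)cc1` gives 57.8% in this assay. On these numbers compound 3 stands second highest of the three. The step of a number 14.1 percentage points lower from compound 1 to compound 3 (beyond the scatter) and the step of a number 12.7 percentage points higher from compound 2 to compound 3 (beyond the scatter) both lie beyond the scatter.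

Compound 4 `CS(=O)(=O)c1ccc(Cc2n[nH]c(=S)n2/N=C/c2ccccc2F)cc1` has not been measured. It differs from compound 3 by 2-fluorophenyl in place of 4-fluorophenyl on a carbon with a double bond to nitrogen. Among the measured compounds shown here, the two measured steps that touch this carbon with a double bond to nitrogen, a number 14.1 percentage points lower from compound 1 to compound 3 (beyond the scatter) and a number 12.7 percentage points higher from compound 2 to compound 3 (beyond the scatter), exchange one whole group for another; neither moves a fluorine within a phenyl ring, so no step directly bears on this change. Both were modest, and an exchange of two fluorophenyl groups is expected to be smaller still, most likely within the scatter and, if anything, slightly downward. The estimated step is a number 4.8 percentage points lower from compound 3 to compound 4 (within the scatter), so compound 4 is expected to give about 53% in this assay, within a range from 38% to 68%.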

Compound 4, a percentage reported as activity, at one concentration (the size of the read-out at that concentration, not a potency): 28.1%
Compound 4: the middle estimate sits 24.9 percentage points above what was measured; the whole stated range lies above it.
By their numbers in this assay, from the lowest: compound 4; then compound 2; then compound 3; then compound 1.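

In this assay the place of the fluorine on the phenyl ring proves to matter at this carbon with a double bond to nitrogen: the two compounds hold the same atoms, joined differently, yet the exchange gives a number 29.7 percentage points lower from compound 3 to compound 4 (beyond the scatter) and so is no neutral swap. The 2-fluorophenyl group also reads lower than pyridin-3-yl with a number 17 percentage points lower from compound 2 to compound 4 (beyond the scatter) and lower than 4-(methylsulfanyl)phenyl with a number 43.8 percentage points lower from compound 1 to compound 4 (beyond the scatter) and this makes compound 4 the weakest of the four. Nothing available here accounts for the drop.

The compounds shown leave open whether the drop belongs to fluorine alone or would also come with 2-chlorophenyl or 2-methoxyphenyl on this carbon. They also leave open whether 3-fluorophenyl would read closer to compound 3 or to compound 4.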